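This account rests on a few compounds, and the source may have more. Where it says the series, first, only, none or still open, it means among the compounds named here.

The measured compounds:

Compound 1, `C#CCSc1nc(Nc2cccc(C(F)(F)F)c2)c(C#N)c(-c2ccccc2)n1`, gives 61100 nM in a functional assay on B16-F10 cells (Mus musculus) for inhibition, read by MTT assay, with a stated time of 72 h; a lower number here means a stronger inhibitor, a higher number a weaker inhibitor.
Compound 2, `COc1ccccc1Nc1nc(SCc2cn(Cc3ccccc3Cl)nn2)nc(-c2ccccc2)c1C#N`, gives 7860 nM in this assay.
Compound 3, `Cc1cccc(Nc2nc(SCc3cn(Cc4ccccc4Cl)nn3)nc(-c3ccccc3)c2C#N)c1`, gives 13500 nM in this assay.

Compound 3 stands second highest of the three numbers in this assay. Its nearest neighbour by number is compound 2, and the step of a 1.7-fold higher number from compound 2 to compound 3 (0.23 log units; within the scatter) lies within the scatter. Compound 1 sits furthest away, with a number beyond the scatter above that of compound 3.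

Compound 4, `Cc1ccccc1Nc1nc(SCc2cn(Cc3ccccc3Cl)nn2)nc(-c2ccccc2)c1C#N`, differs from compound 3 in one place: 2-methylphenyl in place of 3-methylphenyl on a nitrogen on an aromatic ring. Among the compounds with values here, only one measured step bears on an exchange at this nitrogen, namely a 1.7-fold higher number from compound 2 to compound 3 (0.23 log units; within the scatter), which swapped one substituted phenyl for another and stayed within the scatter. Within the data shown here, no measured pair shows a methyl moved from one position to another on that ring. On this basis no step beyond the scatter is expected in this assay, and the expected step is a 1.2-fold lower number from compound 3 to compound 4 (0.09 log units; within the scatter). Compound 4 is therefore estimated to give 11000 nM in this assay, within a range from 4000 nM to 30000 nM.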

Compound 4, half-maximal inhibitory concentration: 2760 nM
Compound 4: middle estimate off by 4.0-fold (0.60 log units), on the high side, outside the stated range (below it).
By their numbers in this assay, from the lowest: compound 4; then compounds 2 and 3 (each within the scatter of the next); then compound 1.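

In this assay, within the data shown here, the position of the methyl on this ring proves to matter: with the same atoms joined differently, 2-methylphenyl in place of 3-methylphenyl gives a 4.9-fold lower number from compound 3 to compound 4 (0.69 log units; beyond the scatter) and is the first exchange at this nitrogen to pass beyond the scatter. Methyl in place of methoxy on an aromatic carbon also counts, giving a 2.8-fold lower number from compound 2 to compound 4 (0.45 log units; beyond the scatter), so the 2-methylphenyl group separates from the 2-methoxyphenyl group, although compound 2 and compound 3 had stayed within the scatter of each other. The data offer no explanation for either step.

From the compounds shown here alone, whether an ethyl group or a chlorine in place of that methyl would lower the number further remains open. Going by these compounds, it is also open whether the (2-methylphenyl)amino group would give a similar step on the core of compound 1.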